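Swapping Methoxy for Chloro on the Aromatic Ring

The source may report more compounds than this note shows. Statements on the series, on what has been measured and on what is new or still open speak of the compounds shown alone.

Measured so far in a physicochemical assay for lipophilicity; on this read-out higher numbers stand for higher lipophilicity and lower numbers for lower lipophilicity:
- compound 1 `C[C@H]1CC[C@@H]2[C@@H](OC(=O)[C@]23CC(c2c(Cl)cccc2Cl)=NO3)[C@]2(C)C(=O)C=C[C@@]12O`: 2.67
- compound 2 `COc1ccc(C2=NO[C@]3(C2)C(=O)O[C@@H]2[C@H]3CC[C@H](C)[C@]3(O)C=CC(=O)[C@@]23C)cc1`: 1.47

Compound 2 holds the lower of the two numbers, at 1.47, and the gap to compound 1 lies beyond the scatter of the measurement. The next compound to consider is compound 3 `C[C@H]1CC[C@@H]2[C@@H](OC(=O)[C@]23CC(c2ccc(Cl)cc2)=NO3)[C@]2(C)C(=O)C=C[C@@]12O`, which has not yet been measured. Its structure departs from compound 2 as follows: chloro in place of methoxy on an aromatic carbon. In short, 4-methoxyphenyl becomes 4-chlorophenyl.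

Within the data shown here, only one measured step bears on this change: a number 1.20 log units lower from compound 1 to compound 2 (beyond the scatter). That large step put 4-methoxyphenyl where compound 1 has a dichlorophenyl group, so it is related to the new change but not identical to it. Compound 3 also carries chlorine on its ring, so in this assay it is expected to rise from compound 2 towards compound 1 at 2.67, without covering the whole distance. The expected change is a number 0.63 log units higher from compound 2 to compound 3 (beyond the scatter). For compound 3 the estimated value is 2.1, with an expected range of 1.7 to 2.5.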

Compound 3, partition coefficient: 2.09
Estimate against measurement, compound 3: 0.01 log units above; the range from low to high includes it.
By their numbers in this assay, from the lowest: compound 2; then compound 3; then compound 1.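

With the rest of the molecule unchanged, a swap of one group at this ring position is enough to shift the result in this assay, giving a number 0.62 log units higher from compound 2 to compound 3 (beyond the scatter). The earlier pair could not show this, since compound 1 and compound 2 differ in both the kind of group on the ring and how those groups are arranged. The other new step, a number 0.58 log units lower from compound 1 to compound 3 (beyond the scatter), places compound 3 between them, dividing the large gap into two modest parts, although no accompanying measurement explains this order.

Still open, on these data alone, is how an amine, a carboxylic acid or a longer chain such as ethoxy would read at this same ring position, which would test whether the order seen with methoxy and chloro extends to other groups. Also open, as far as these compounds go, is how much of the difference between 2,6-dichlorophenyl and 4-chlorophenyl belongs to the count of chlorine atoms and how much to where they sit on the ring.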